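Ester chain in place of ring on the shared core

The compounds below may be only part of what the source reports. "The series", "measured", "known", "first", "only" and "open" are said of these compounds alone.

Compound 2 `COc1ccc(-c2csc(N/N=C/c3ccc4cc(OC)ccc4c3)n2)cc1` gives 79.7% in an assay on isolated protein for inhibition of Amine oxidase [flavin-containing] B (Homo sapiens), tested at 1 mM (a lower number here means a stronger effect, a higher number a weaker effect of the compound at the concentration tested), the highest of the two numbers measured; compound 1 `COc1cccc(-c2csc(N/N=C/c3ccc4cc(OC)ccc4c3)n2)c1` gives 68.9%. Going by the values given here, the only measured step, a number 10.8 percentage points higher from compound 1 to compound 2 (beyond the scatter), moves a methoxy group on the same ring and says nothing about removing that ring. Compound 3 `CCOC(=O)Cc1csc(N/N=C/c2ccc3cc(OC)ccc3c2)n1` differs from compound 2 by (ethoxycarbonyl)methyl in place of 4-methoxyphenyl on an aromatic carbon. Among the compounds with values here, with no step of this kind measured, the size of the change in this assay cannot be read from the series; a drop beyond the scatter is expected, since the replaced group is the larger one. Compound 3 is estimated at 50% (range 20% to 80%), an expected step of a number 29.7 percentage points lower from compound 2 to compound 3 (beyond the scatter).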

Compound 3, a percentage reported as inhibition, at one concentration (the size of the read-out at that concentration, not a potency): 96.5%
Beside the measured number, compound 3's estimate is 46.5 percentage points below it, outside the stated range (above it).
By their numbers in this assay, from the lowest: compound 1; then compound 2; then compound 3.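

In this assay, a six-membered aromatic ring at this aromatic carbon is not required for a high number: (ethoxycarbonyl)methyl gives a step of a number 16.8 percentage points higher from compound 2 to compound 3 (beyond the scatter) and of a number 27.6 percentage points higher from compound 1 to compound 3 (beyond the scatter). Both steps are beyond the scatter, and both go the same way, so the open chain ends above either methoxyphenyl group. Nothing available explains this rise.

The compounds shown leave open whether the ester or the loss of the ring carries the step. A carboxylic acid, an amide or a longer chain at this position would help separate the two.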